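The compounds below may be only part of what the source reports. "The series", "measured", "known", "first", "only" and "open" are said of these compounds alone.

In a toxicity assay on HT-29 cells (Homo sapiens) for cytotoxicity (on this read-out lower numbers stand for higher toxicity in this test and higher numbers for lower toxicity in this test), compound 1 (`CN1C(=S)[C@@H](NC(=O)c2nc(Cc3ccccc3)n(C)n2)COc2ccccc21`) gives > 100000 nM as a limit of the assay, not a number. Compound 2 (`CCCn1nc(C(=O)N[C@H]2COc3ccccc3N(C)C2=S)nc1Cc1ccccc1`) gives > 100000 nM which is also a limit. Compound 3 (`CN1C(=S)[C@@H](NC(=O)c2nc(Cc3ccccc3)n(CCCF)n2)COc2ccccc21`) gives > 100000 nM and this too is a limit. Compound 3 therefore has no exact value, and it shares its position with the other two compounds (the limit of > 100000 nM in this assay, at which 3 of the 3 values shown sit).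

Compound 4 (`CN1C(=S)[C@@H](NC(=O)c2nc(Cc3ccccc3)n(CCCO)n2)COc2ccccc21`) has not yet been measured and differs from compound 3 by one exchange (hydroxy in place of fluoro on a saturated chain carbon, three bonds along the chain from an aromatic nitrogen): hydroxy in place of fluoro on a saturated chain carbon, three bonds along the chain from an aromatic nitrogen. This turns 3-fluoropropyl into 3-hydroxypropyl.

For the measured compounds named here, three measured steps bear on this exchange: (a step that the two limits leave unreadable from compound 1 to compound 2), (a step that the two limits leave unreadable from compound 1 to compound 3) and (a step that the two limits leave unreadable from compound 2 to compound 3). The last is the closest guide, as it changes the same carbon. All three have limits at both ends, so none offers a size to carry over.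

The expected change (a number no higher from compound 3 to compound 4 (the limit leaves the size open)) is none beyond the usual scatter, with no direction favoured. Compound 4 is estimated at 100000 nM with an expected range from 50000 nM to 200000 nM and the assay will most likely report only a limit.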

Compound 4, half-maximal cytotoxic concentration: > 100000 nM
Compound 4 ended at the assay's limit (the forecaster's own chance of this, stated with the estimate: 90%); the middle value sits exactly at the limit.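

Compound 4 also ends at a limit of the assay rather than a number, just as compounds 1, 2 and 3 do, so no step among these four compounds can be read: the limit of > 100000 nM in this assay, at which 4 of the 4 values shown sit. The compounds shown leave open whether changing the group on the aromatic nitrogen alters the result at all in this assay.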